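Propyl in place of isopropyl: expectation for compound 4

The source may hold more compounds than are shown below. What is called first, only, known or untested is meant among the compounds shown, and "the series" means these compounds.

In a functional assay on DU-145 cells (Homo sapiens) for cytotoxicity, read by MTT assay, with a stated time of 72 h (a higher number here means a weaker inhibitor, a lower number a stronger inhibitor), compound 1 `CC(C)NC(=S)N/N=C1\CC(c2ccc(O)cc2)Oc2cc(O)ccc21` gives 60400 nM, compound 2 `CC(C)(C)NC(=S)N/N=C1\CC(c2ccc(O)cc2)Oc2cc(O)ccc21` gives 42900 nM and compound 3 `Oc1ccc(C2C/C(=N\NC(=S)N3CCCCC3)c3ccc(O)cc3O2)cc1` gives 55300 nM. Compound 1 therefore stands level with the other two, all three lying within the scatter of one another. Compound 4 `CCCNC(=S)N/N=C1\CC(c2ccc(O)cc2)Oc2cc(O)ccc21` differs from compound 1 as follows: propyl in place of isopropyl on an amide-type nitrogen. That is propyl in place of isopropyl on an amide-type nitrogen. For the measured compounds named here, no measured step makes this exact change. The closest steps alter the same substituent: a 1.4-fold lower number from compound 1 to compound 2 (0.15 log units; within the scatter), a 1.1-fold lower number from compound 1 to compound 3 (0.04 log units; within the scatter) and a 1.3-fold higher number from compound 2 to compound 3 (0.11 log units; within the scatter). None of these exceeds the scatter, so no shift beyond the scatter is expected in either direction. The expected step is a 1.1-fold lower number from compound 1 to compound 4 (0.04 log units; within the scatter). The estimate for compound 4 is 55000 nM, with an expected range of 28000 nM to 100000 nM.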

Compound 4, half-maximal inhibitory concentration: 74700 nM
For compound 4 the middle estimate is 1.4-fold (0.13 log units) below the measured one; the range from low to high includes it.
By their numbers in this assay, from the lowest: compounds 2, 3, 1 and 4 (each within the scatter of the next).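

Propyl in place of isopropyl on an amide-type nitrogen gives no shift beyond the scatter in this assay (a 1.2-fold higher number from compound 1 to compound 4 (0.09 log units; within the scatter)). Propylamino also stays within the scatter of the piperidin-1-yl and (tert-butyl)amino compounds (a 1.4-fold higher number from compound 3 to compound 4 (0.13 log units; within the scatter); a 1.7-fold higher number from compound 2 to compound 4 (0.24 log units; within the scatter)), so the linear chain, the branched chains and the piperidine are not told apart by these numbers. No independent measurement bears on this result.

Open, as far as these compounds go, is whether a longer chain such as octyl, or a propyl chain ending in an amine or a carboxylic acid, would move the number beyond the scatter.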